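From a chlorobenzyl amide to a branched ester amide

The source may report more compounds than this note shows. Statements on the series, on what has been measured and on what is new or still open speak of the compounds shown alone.

Three compounds have been measured in a functional assay on HL-60 cells (Homo sapiens), with a stated time of 4 days; on this read-out higher numbers stand for weaker inhibition and lower numbers for stronger inhibition:

compound 1 `CCCCCCNC(=O)c1[nH]cnc1C(=O)Nc1ccc(Cl)c(Cl)c1` gives 7800 nM
compound 2 `O=C(Nc1ccc(Cl)c(Cl)c1)c1nc[nH]c1C(=O)NCc1ccc(Cl)cc1` gives 8800 nM
compound 3 `COC(=O)[C@@H](C)NC(=O)c1[nH]cnc1C(=O)Nc1ccc(Cl)c(Cl)c1` gives only a limit, > 62500 nM

Compound 2 holds the highest of the two numbers that are not limits, yet it sits within the scatter of compound 1, as the step of a 1.1-fold higher number from compound 1 to compound 2 (0.05 log units; within the scatter) shows. Compound 4 `COC(=O)[C@@H](NC(=O)c1[nH]cnc1C(=O)Nc1ccc(Cl)c(Cl)c1)C(C)C` is made from compound 2 by the change (1-(methoxycarbonyl)-2-methylpropyl in place of 4-chlorobenzyl on an amide-type nitrogen).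

Going by the values given here, two measured steps bear on this change. The step of an at least 7.1-fold higher number from compound 2 to compound 3 (0.85 log units; beyond the scatter) and the step of an at least 8.0-fold higher number from compound 1 to compound 3 (0.90 log units; beyond the scatter) both lead to compound 3, whose value is the limit (the limit of > 62500 nM in this assay, at which 1 of the 3 values shown sits), so both steps are at least modest and both point towards weaker inhibition. Compound 3 carries 1-(methoxycarbonyl)ethyl on an amide-type nitrogen whose other neighbour is a carbonyl carbon, the same place where compound 4 carries 1-(methoxycarbonyl)-2-methylpropyl. On that basis compound 4 is expected to show a step of a 6.8-fold higher number from compound 2 to compound 4 (0.83 log units; beyond the scatter) towards weaker inhibition in this assay. The estimate for compound 4 is 60000 nM, within a range from 15000 nM to 250000 nM, and a reading that is only a limit is thought fairly likely.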

Compound 4, half-maximal inhibitory concentration: > 62500 nM
Compound 4 was reported as a limit; the forecaster's own chance of this, stated with the estimate: 55%; middle value at least 1.0-fold (0.01 log units) from the limit.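

In this assay compound 4 gives only a limit, > 62500 nM, so a second compound now sits at that limit: the limit of > 62500 nM in this assay, at which 2 of the 4 values shown sit.

Replacing the 4-chlorobenzyl on the amide-type nitrogen with 1-(methoxycarbonyl)-2-methylpropyl gives an at least 7.1-fold higher number from compound 2 to compound 4 (0.85 log units; beyond the scatter), and replacing hexyl at the same place gives an at least 8.0-fold higher number from compound 1 to compound 4 (0.90 log units; beyond the scatter), both towards weaker inhibition. The loss of inhibition seen with 1-(methoxycarbonyl)ethyl is therefore not confined to that one group: among the four compounds, both groups carrying a methoxycarbonyl sit at the limit, while hexyl and 4-chlorobenzyl give measurable values.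

The step between the two compounds at the limit cannot be read, so these data do not tell how the 2-methylpropyl side chain compares with the smaller 1-(methoxycarbonyl)ethyl group. From the compounds shown here alone, it also remains open whether the loss goes with the methyl ester itself, and a carboxylic acid in its place, or an amine at the end of a hexyl chain, would be needed to separate that from the rest of the group.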